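The source may report more compounds than this note shows. Statements on the series, on what has been measured and on what is new or still open speak of the compounds shown alone.

Compounds measured in an assay on membranes from CHO cells for displacement of a labelled ligand from adenosine receptor A1 (Homo sapiens), read by scintillation counting, with a stated time of 60 min, tested at 1 uM; a higher number here means more inhibition at the concentration tested (going by the name of the read-out), a lower number less inhibition:

compound 1, `CC1=C(C(N)=O)C(c2ccsc2)NC(=O)N1`, gives 2%
compound 2, `CCC(CC)OC(=O)C1=C(C)NC(=O)NC1c1ccsc1`, gives 22%
compound 3, `CCC(C)OC(=O)C1=C(C)NC(=O)NC1c1ccsc1`, gives 5%

Compound 3 holds the second highest of the three numbers. Its nearest neighbour is compound 1, and the gap between them, a number 3 percentage points higher from compound 1 to compound 3 (within the scatter), lies within the scatter. Its furthest is compound 2, and the step of a number 17 percentage points lower from compound 2 to compound 3 (beyond the scatter) is beyond the scatter, though modest.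

Compound 4, `CC1=C(C(=O)OCC2CCC2)C(c2ccsc2)NC(=O)N1`, has not yet been measured. It differs from compound 3 in one place: cyclobutylmethyl in place of sec-butyl on an oxygen next to a carbonyl group.

Within the data shown here, two measured steps bear on this change, both at the oxygen next to the carbonyl group. The step of a number 20 percentage points higher from compound 1 to compound 2 (beyond the scatter) was modest, and a number 17 percentage points lower from compound 2 to compound 3 (beyond the scatter) was likewise modest in the other direction. The remaining step, a number 3 percentage points higher from compound 1 to compound 3 (within the scatter), stayed within the scatter. The group that enters in compound 4 is of the same carbon count as the pentan-3-yl group of compound 2, so some rise from compound 3 seems possible, yet the evidence is thin and the steps are small.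

For compound 4 the expected step in this assay is a number 7 percentage points higher from compound 3 to compound 4 (within the scatter), within the scatter. The estimate for compound 4 is 12%, with a range from 0% to 30%.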

Compound 4, a percentage reported as inhibition, at one concentration (the size of the read-out at that concentration, not a potency): 48%
Estimate against measurement, compound 4: 36 percentage points below; the whole stated range lies below it.
By their numbers in this assay, from the lowest: compounds 1 and 3 (each within the scatter of the next); then compound 2; then compound 4.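

In this assay, among these compounds, the group on the oxygen next to the carbonyl group proves able to shift the read-out far more than the earlier compounds suggested: cyclobutylmethyl in place of sec-butyl gives a number 43 percentage points higher from compound 3 to compound 4 (beyond the scatter). Carbon count alone does not set the result in this small set, since cyclobutylmethyl also surpasses pentan-3-yl, which carries the same number of carbons, with a number 26 percentage points higher from compound 2 to compound 4 (beyond the scatter), and the comparison with the primary amide gives a number 46 percentage points higher from compound 1 to compound 4 (beyond the scatter). The ring-bearing ester thus stands apart from both open-chain esters and the amide, but nothing shown explains this difference.

The compounds shown leave open whether the four-membered ring itself matters or whether an unbranched attachment at the oxygen would be enough, a question that an unbranched pentyl ester, a cyclopropylmethyl ester or a cyclobutyl ester would help to separate. On these data alone, each figure is also a single inhibition reading at one concentration, so the potency of compound 4 at this receptor and its behaviour at other adenosine receptors remain open.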